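The source may hold more compounds than are shown below. What is called first, only, known or untested is meant among the compounds shown, and "the series" means these compounds.

Series in a functional assay on A549 cells (Homo sapiens) for antiproliferative activity, read by MTT assay, with a stated time of 48 h; on this read-out lower numbers stand for stronger inhibition and higher numbers for weaker inhibition
- compound 1 `CCCCCCCCCCCCOc1ccc(C(=O)/C=C/c2c(/C=C/c3ccc(OC)cc3)cc(OC)cc2OC)cc1` gives 7.9 ug/mL
- compound 2 `CCCCOc1ccc(C(=O)/C=C/c2c(/C=C/c3ccc(OC)cc3)cc(OC)cc2OC)cc1` gives 8.7 ug/mL
- compound 3 `COc1ccc(/C=C/c2cc(OC)cc(OC)c2/C=C/C(=O)c2cccc(Cl)c2)cc1` gives 5.6 ug/mL

Compound 3 stands within the scatter of both compound 1 and compound 2, so the three values form one group with no order to read.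

Compound 4 `COc1ccc(/C=C/c2cc(OC)cc(OC)c2/C=C/C(=O)c2ccccc2)cc1` differs from compound 3 by a single change (hydrogen in place of chloro on an aromatic carbon), hydrogen in place of chloro on an aromatic carbon, meta to a large group. Going by the values given here, no measured step removes the chloro alone. The closest evidence is the change of group on the carbonyl carbon, a 1.6-fold lower number from compound 2 to compound 3 (0.19 log units; within the scatter) as measured, where 3-chlorophenyl replaces 4-butoxyphenyl. The chain change, a 1.1-fold higher number from compound 1 to compound 2 (0.04 log units; within the scatter) as measured, is further from this position and also small. Neither step leaves the scatter, so these data give no reason to expect a large move here.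

In this assay the estimated change is a 1.2-fold higher number from compound 3 to compound 4 (0.06 log units; within the scatter) and no step beyond the scatter is expected.

For compound 4 the expected value is 6.5 ug/mL with an estimated range of 3.5 ug/mL to 12 ug/mL on this read-out.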

Compound 4, half-maximal inhibitory concentration: 3.9 ug/mL
For compound 4 the middle estimate is 1.7-fold (0.22 log units) above the measured one, within the range that was stated.
By their numbers in this assay, from the lowest: compounds 4, 3, 1 and 2 (each within the scatter of the next, the first and the last beyond it).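

In this assay hydrogen in place of chloro on this aromatic carbon, meta to a large group, gives a 1.4-fold lower number from compound 3 to compound 4 (0.16 log units; within the scatter) and so leaves compound 4 in one group with compound 3. Going by these compounds alone, the phenyl of compound 4 also provides the first step to leave the scatter, with hydrogen in place of butoxy giving a 2.2-fold lower number from compound 2 to compound 4 (0.35 log units; beyond the scatter), although this step is only modest. No evidence available here bears on either step.

The position is shown with only chloro, butoxy and dodecyloxy-type chains on the ring, so the effect of an amine or a carboxylic acid on this aromatic carbon remains open. As far as these compounds go, whether a methoxy group at the place held by chloro would stay within the scatter of compound 4 also remains open.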